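This account rests on a few compounds, and the source may have more. Where it says the series, first, only, none or still open, it means among the compounds named here.

Of the compounds shown here, three with a shared core have been tested in a toxicity assay on NIH3T3 cells (Mus musculus) for cytotoxicity, read by resazurin assay; on this read-out higher numbers stand for an effect only at larger amounts of compound and lower numbers for an effect already at smaller amounts: compound 1 (`COC(=O)c1ccc(NCc2cncn2Cc2cccc([N+](=O)[O-])c2)cc1-c1ccccc1`), compound 2 (`COC(=O)c1ccc(NCc2cncn2Cc2ccc([N+](=O)[O-])cc2)cc1-c1ccccc1`) and compound 3 (`COC(=O)c1ccc(NCc2cncn2Cc2ccc(Br)cc2)cc1-c1ccccc1`). Compound 1 gives > 10000 nM, which is a limit of the assay and not a number. Compound 2 gives > 10000 nM, again a limit. Compound 3 gives > 10000 nM, so it too stands only at a limit. The series therefore offers the limit of > 10000 nM in this assay, at which 3 of the 3 values shown sit, and no measured number.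

Compound 4 (`COC(=O)c1ccc(NCc2cncn2Cc2cccc(C(C)(C)C)c2)cc1-c1ccccc1`) carries 3-(tert-butyl)phenyl in place of 4-bromophenyl on a saturated chain carbon bound to an aromatic nitrogen. Within the data shown here, three measured steps bear on this change, as each alters the same benzyl-type substituent: a step that the two limits leave unreadable from compound 1 to compound 2, a step that the two limits leave unreadable from compound 1 to compound 3 and a step that the two limits leave unreadable from compound 2 to compound 3. None of them has a size that can be read, so they give no measure of how far such a change might carry.

In this assay the expected outcome is a step that the limit leaves unreadable from compound 3 to compound 4, and no shift beyond the scatter is expected in either direction. The estimate for compound 4 is 12000 nM, with an expected range from 4000 nM to 30000 nM, and the most likely report is once more a limit.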

Compound 4, half-maximal effective concentration: > 1000 nM
Compound 4 gave a limit, no number; the forecaster's own chance of this, stated with the estimate: 80%; the middle value is on the limit's open side.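

In this assay compound 4 gives > 1000 nM, which is a limit of the assay and not a number. Among these compounds, no step from compound 4 to compound 1, compound 2 or compound 3 can be read, as each of the four compounds stands only at a limit. The compounds shown leave open at what concentration any of them has an effect in this assay, and whether swapping these benzyl-type substituents changes that concentration at all.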